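A few compounds are considered here, and "the series" means these few. Any claim that something is new, unique, unknown or untested is made for them only; others in the source may bear on it.

Compound 1 `Cc1nccnc1C1CN2CCC1CC2` gives 4% in a functional assay on A9L-m1 cells with A9 (Mus musculus) as the target; a higher number here means a larger maximal response, a lower number a smaller maximal response. Compound 2 `CCCCCOc1nccnc1C1CN2CCC1CC2` gives 32% in this assay, the step being a number 28 percentage points higher from compound 1 to compound 2 (beyond the scatter). Among the measured compounds shown here, compound 2 therefore holds the higher of the two numbers so far. Compound 3 `CCCCCCSc1nccnc1C1CN2CCC1CC2` differs from compound 2 by hexylsulfanyl in place of pentyloxy on an aromatic carbon. For the measured compounds named here, no measured step exchanges these two groups; the only known step, a number 28 percentage points higher from compound 1 to compound 2 (beyond the scatter), concerns methyl and pentyloxy and bears on the new change only in that a chain on that carbon already gave the larger response. Compound 3 is expected to give 30%, estimated between 10% and 55%. The expected step is a number 2 percentage points lower from compound 2 to compound 3 (within the scatter), within the scatter.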

Compound 3, largest response reached (reported as maximum), in percent of the reference or control that the assay uses: 16%
For compound 3 the middle estimate is 14 percentage points above the measured one; the range from low to high includes it.
By their numbers in this assay, from the lowest: compound 1; then compound 3; then compound 2.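

In this assay, the chain on this aromatic carbon cannot be exchanged freely: hexylsulfanyl in place of pentyloxy gives a number 16 percentage points lower from compound 2 to compound 3 (beyond the scatter), so the maximal response depends on more than the presence of a chain. Hexylsulfanyl still retains a gain over methyl, with a number 12 percentage points higher from compound 1 to compound 3 (beyond the scatter). No available evidence accounts for the difference between these two chains.

The step from pentyloxy to hexylsulfanyl changes both the linking atom and the chain length, and the compounds shown do not separate the two. Pentylsulfanyl or hexyloxy on the same carbon would do so.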